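Benzyl in place of 4-chlorophenyl: notes on compound 3

The source may hold more compounds than are shown below. What is called first, only, known or untested is meant among the compounds shown, and "the series" means these compounds.

Compound 1 `CC1(C)CC(NC(=O)Nc2ccc(Cl)cc2)c2cc(F)ccc2O1`: 30000 nM
Compound 2 `CC1(C)CC(NC(=O)Nc2ccc(Cl)cc2)c2cc(Cl)ccc2O1`: 33000 nM

Among the compounds with values here, in a functional assay on T98G cells (Homo sapiens) for inhibition, read by MTT assay, with a stated time of 72 h (on this read-out lower numbers stand for stronger inhibition and higher numbers for weaker inhibition), compound 1 holds no rank of its own, since its single comparison is a 1.1-fold higher number from compound 1 to compound 2 (0.04 log units; within the scatter). That step, chloro in place of fluoro on an aromatic carbon, is the only one measured, and it leaves the group on the amide-type nitrogen untouched.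

Compound 3 `CC1(C)CC(NC(=O)NCc2ccccc2)c2cc(F)ccc2O1` carries benzyl in place of 4-chlorophenyl on an amide-type nitrogen. Within the data shown here, no measured step covers this change, so the data say little about its size or direction. In this assay only a small move towards a higher number is expected, with wide uncertainty on either side. The expected change is a 1.3-fold higher number from compound 1 to compound 3 (0.12 log units; within the scatter). For compound 3 the estimated value is 40000 nM. The expected range for compound 3 runs from 15000 nM to 100000 nM.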

Compound 3, half-maximal inhibitory concentration: 49000 nM
Compound 3: middle estimate off by 1.2-fold (0.09 log units), on the low side; measured number inside the range.
By their numbers in this assay, from the lowest: compounds 1, 2 and 3 (each within the scatter of the next).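

Benzyl in place of 4-chlorophenyl on an amide-type nitrogen gives a 1.6-fold higher number from compound 1 to compound 3 (0.21 log units; within the scatter) in this assay and so provides the first reading at this place, where the earlier compounds differed only on an aromatic carbon. This exchange removes the chlorine and keeps one six-membered aromatic ring of carbon only, yet compound 1 and compound 3 cannot be told apart in this assay. The step therefore gives no sign that either group is preferred on that nitrogen, and no measurement at hand accounts for the result.

Plain phenyl on that nitrogen would separate the loss of the chlorine from the change to benzyl. From the compounds shown here alone, whether a longer chain, an amine or a carboxylic acid at the same place would move the number beyond the scatter also remains open.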